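Dropping One Fluorine from a Sulfone Aryl Ring

The compounds below may be only part of what the source reports. "The series", "measured", "known", "first", "only" and "open" are said of these compounds alone.

Compound 1 `CC1CCN(c2c(S(=O)(=O)c3cc(Cl)cc(Cl)c3)cnc3ccc(F)cc23)CC1`: 69%
Compound 2 `CC1CCN(c2c(S(=O)(=O)c3cccc(Cl)c3)cnc3ccc(F)cc23)CC1`: 92%
Compound 3 `CC1CCN(c2c(S(=O)(=O)c3ccc(F)c(F)c3)cnc3ccc(F)cc23)CC1`: 82%

In an assay on isolated protein for displacement of a labelled ligand from metabotropic glutamate receptor 5 (Homo sapiens), with a stated time of 60 min, tested at 1 uM (a higher number here means more inhibition at the concentration tested (going by the name of the read-out), a lower number less inhibition), compound 3 stands second highest of the three measured numbers. Its gap to the highest compound lies within the scatter (a number 10 percentage points lower from compound 2 to compound 3 (within the scatter)), while the step up from the lowest compound is beyond it (a number 13 percentage points higher from compound 1 to compound 3 (beyond the scatter)).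

Compound 4 `CC1CCN(c2c(S(=O)(=O)c3cccc(F)c3)cnc3ccc(F)cc23)CC1` is compound 3 with one change: hydrogen in place of fluoro on an aromatic carbon. Among the compounds with values here, two measured steps bear on this. Removing one halogen from a twice-halogenated ring gave a rise (a number 23 percentage points higher from compound 1 to compound 2 (beyond the scatter)), whereas swapping one halogen pattern for another changed little (a number 10 percentage points lower from compound 2 to compound 3 (within the scatter)). A small upward step, or none beyond the scatter, is therefore expected: a number 6 percentage points higher from compound 3 to compound 4 (within the scatter). Compound 4 is estimated at 88%, within 76% to 96%.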

Compound 4, a percentage reported as inhibition, at one concentration (the size of the read-out at that concentration, not a potency): 76%
Estimate against measurement, compound 4: 12 percentage points above; the range from low to high includes it.
By their numbers in this assay, from the lowest: compounds 1, 4, 3 and 2 (each within the scatter of the next, the first and the last beyond it).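

In this assay, replacing one fluoro of the 3,4-difluorophenyl group with hydrogen gives a step within the scatter (a number 6 percentage points lower from compound 3 to compound 4 (within the scatter)), so this removal of a halogen does not repeat the clear rise seen between compound 1 and compound 2. The halogen itself does count on the singly substituted ring, as fluoro in place of chloro gives a step beyond the scatter (a number 16 percentage points lower from compound 2 to compound 4 (beyond the scatter)), while the step from the dichloro compound stays within it (a number 7 percentage points higher from compound 1 to compound 4 (within the scatter)). No measurement shown here explains these steps.

Open, going by these compounds, is how a methoxy group, a nitrile or an amine would fare in place of this halogen on the sulfone's aryl ring. These single-concentration percentages also give no potency for any of the compounds.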